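The compounds below may be only part of what the source reports. "The series", "measured", "known", "first", "only" and "open" are said of these compounds alone.

Series notes. Compound 1, `ClCc1ccccc1Cn1cnc2c(Cl)nc(Cl)nc21`, and compound 2, `ClCc1ccccc1Cn1cnc2c(Cl)ncnc21`, share a core and differ in a single place; compound 3, `ClCc1ccc(Cn2cnc3nc(Cl)nc(Cl)c32)cc1`, has the same atoms as compound 1 joined differently, and the difference between the two cores is not broken down here. In a functional assay on SF-295 cells (Homo sapiens) for cytotoxicity, read by sulforhodamine B assay, with a stated time of 48 h (on this read-out lower numbers stand for higher toxicity in this test and higher numbers for lower toxicity in this test), compound 1 gives 6020 nM. In this assay compound 2 gives 51300 nM. The change from compound 1 to compound 2 is hydrogen in place of chloro on an aromatic carbon, and it made an 8.5-fold higher number from compound 1 to compound 2 (0.93 log units; beyond the scatter). In this assay compound 3 gives 5880 nM, a number that stands within the usual scatter of the number for compound 1, so no order between compound 1 and compound 3 is read from these two values; the gap from compound 3 to compound 2 lies beyond the scatter.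

Compound 4, `ClCc1ccc(Cn2cnc3ncnc(Cl)c32)cc1`, is not yet measured. It differs from compound 3 by hydrogen in place of chloro on an aromatic carbon. Going by the values given here, this is the same change as the one between compound 1 and compound 2, occurring twice among the compounds here, and the surroundings of the place match word for word. Among the compounds with values here, only one measured instance exists, so the expectation rests on a single step. Within the data shown here, a step of the same size is expected, because the one measured example gave an 8.5-fold higher number from compound 1 to compound 2 (0.93 log units; beyond the scatter) from a starting number close to that of compound 3. The expected step is an 8.5-fold higher number from compound 3 to compound 4 (0.93 log units; beyond the scatter). Compound 4 is thus estimated at 50000 nM in this assay, with an expected range from 22000 nM to 110000 nM.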

Compound 4, concentration lethal to 50% of the cells: 17000 nM
Beside the measured number, compound 4's estimate is 2.9-fold (0.47 log units) above it; the measured number lies below the stated range.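

In this assay, hydrogen in place of chloro on the aromatic carbon between two ring nitrogen atoms gave a 2.9-fold higher number from compound 3 to compound 4 (0.46 log units; beyond the scatter), so the change moved the number the same way on both cores, but not by the same amount: the same change on two cores in this assay, an 8.5-fold higher number (0.93 log units; beyond the scatter) from compound 1 to compound 2 and a 2.9-fold higher number (0.46 log units; beyond the scatter) from compound 3 to compound 4, 2.9-fold (0.47 log units) apart, beyond the scatter of two such steps. On these two pairs, the direction of the change carries from the core of compound 1 to the core of compound 3, whereas the size of the step does not, and a step measured on one of these cores is a poor stand-in for the step on the other. Two pairs do not show which difference between the cores goes with the difference in step size, and they give no rule for any further core.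

Only chloro and hydrogen appear at this place in the compounds shown, leaving open how an amine, a methoxy group or a thiol there would read in this assay on either core. All four compounds also keep the chloromethyl group, and how the numbers would stand with a methyl or hydroxymethyl group in its place remains an open question.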